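Swapping the Aryl Group: Compound 3 to Compound 4

This account rests on a few compounds, and the source may have more. Where it says the series, first, only, none or still open, it means among the compounds named here.

Of the compounds shown here, three sharing one core have been measured in an ADME assay on cells (Macrophage) for cytotoxicity, read by MTT assay, with a stated time of 24 h; on this read-out higher numbers stand for lower toxicity in this test and lower numbers for higher toxicity in this test. Compound 1 `COc1ccc(/C=C/C(=O)NNC(=O)c2ccc3c(c2)OCCO3)cc1` gives 319000 nM, compound 2 `Cc1ccccc1/C=C/C(=O)NNC(=O)c1ccc2c(c1)OCCO2` gives 268000 nM, and compound 3 `O=C(/C=C/c1ccccc1Cl)NNC(=O)c1ccc2c(c1)OCCO2` gives 285000 nM. Compound 3 sits within the scatter of both of the others: the step of a 1.1-fold lower number from compound 1 to compound 3 (0.05 log units; within the scatter) and the step of a 1.1-fold higher number from compound 2 to compound 3 (0.03 log units; within the scatter) are each within it, as is a 1.2-fold lower number from compound 1 to compound 2 (0.08 log units; within the scatter). Every measured change in this set has been an exchange of the aryl group on the double-bonded chain carbon, and none has moved the number in this assay beyond the scatter. Compound 4 `O=C(/C=C/c1cccc(F)c1)NNC(=O)c1ccc2c(c1)OCCO2` continues the same kind of exchange: 3-fluorophenyl in place of 2-chlorophenyl on a double-bonded chain carbon bound to a double-bonded chain carbon. Because a 1.1-fold lower number from compound 1 to compound 3 (0.05 log units; within the scatter) and a 1.1-fold higher number from compound 2 to compound 3 (0.03 log units; within the scatter) both lie within the scatter, and because a 1.2-fold lower number from compound 1 to compound 2 (0.08 log units; within the scatter) does as well, no step beyond the scatter is expected in this assay for compound 4. The expected step is no change at the digits printed from compound 3 to compound 4 (within the scatter). Compound 4 is therefore estimated at 285000 nM, with a range from 150000 nM to 550000 nM.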

Compound 4, half-maximal cytotoxic concentration: 221000 nM
For compound 4 the middle estimate is 1.3-fold (0.11 log units) above the measured one; measured number inside the range.
By their numbers in this assay, from the lowest: compounds 4, 2, 3 and 1 (each within the scatter of the next).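

Compound 4 brings a fluorine-bearing aryl group to this place on the double-bonded chain carbon, and in this assay each of its steps stays within the scatter: a 1.3-fold lower number from compound 3 to compound 4 (0.11 log units; within the scatter), a 1.2-fold lower number from compound 2 to compound 4 (0.08 log units; within the scatter) and a 1.4-fold lower number from compound 1 to compound 4 (0.16 log units; within the scatter). The four substituted phenyl groups shown, 4-methoxyphenyl, 2-methylphenyl, 2-chlorophenyl and 3-fluorophenyl, therefore cannot be told apart in this test, and that now holds for a fluoro-substituted ring as well. Nothing available accounts for this lack of separation.

Every group shown at this place is a substituted phenyl ring, so what an amine, a carboxylic acid or a longer chain would do there remains open. As far as these compounds go, whether any exchange at this place can move the number beyond the scatter also remains open.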